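Hydrogen to methoxycarbonyl on the aromatic ring of compound 1

The source may hold more compounds than are shown below. What is called first, only, known or untested is meant among the compounds shown, and "the series" means these compounds.

Compound 1 `NS(=O)(=O)NCC1CCN(c2cc(-c3ccccc3)ncn2)CC1` carries only hydrogen at the aromatic carbon in question. In a functional assay on M21 cells (Homo sapiens) for antiproliferative activity, read by sulforhodamine B assay, with a stated time of 48 h (a higher number here means a weaker inhibitor of growth, a lower number a stronger inhibitor of growth), compound 1 gives only a limit, > 100000 nM, not a number. Compound 2 `Cc1ccc(-c2cc(N3CCC(CNS(N)(=O)=O)CC3)ncn2)cc1` gives 71000 nM in this assay, and compound 3 `NS(=O)(=O)NCC1CCN(c2cc(-c3ccc(C(F)(F)F)cc3)ncn2)CC1` gives 43100 nM. The step of an at least 1.4-fold lower number from compound 1 to compound 2 (0.14 log units; that floor lies within the scatter) and the step of an at least 2.3-fold lower number from compound 1 to compound 3 (0.36 log units; beyond the scatter) both point toward a lower number once a group sits at this carbon, though each rests on the limit (the limit of > 100000 nM in this assay, at which 1 of the 3 values shown sits). Compound 4 `COC(=O)c1ccc(-c2cc(N3CCC(CNS(N)(=O)=O)CC3)ncn2)cc1` differs from compound 1 by methoxycarbonyl in place of hydrogen on an aromatic carbon. Both measured steps bear on this change, so an at least modest lowering is expected. The expected step is an at least 2.5-fold lower number from compound 1 to compound 4 (0.39 log units; beyond the scatter). Compound 4 is therefore estimated at 40000 nM, with a range from 15000 nM to 110000 nM.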

Compound 4, concentration for 50% growth inhibition: 14100 nM
Compound 4: middle estimate off by 2.8-fold (0.45 log units), on the high side; measured number outside the range, below it.
By their numbers in this assay, from the lowest: compound 4; then compounds 3 and 2 (each within the scatter of the next). At a limit, above all of these: compound 1.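

In this assay, among these compounds, this carbon separates the groups more than the earlier compounds showed: methoxycarbonyl gives a 3.1-fold lower number from compound 3 to compound 4 (0.49 log units; beyond the scatter) and a 5.0-fold lower number from compound 2 to compound 4 (0.70 log units; beyond the scatter), whereas the step between the methyl and trifluoromethyl compounds lay within the scatter. Against the unsubstituted compound, the reading is an at least 7.0-fold lower number from compound 1 to compound 4 (0.85 log units; beyond the scatter), which gives only a floor. Compound 1 has a limit, not a number: the limit of > 100000 nM in this assay, at which 1 of the 4 values shown sits.

The compounds shown leave open whether the lowering is specific to methoxycarbonyl or would also appear with a carboxylic acid, a primary amide or a nitrile at this carbon.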